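The compounds below may be only part of what the source reports. "The series", "measured", "known", "first", "only" and "open" are said of these compounds alone.

Measured in a functional assay on U-373MG ATCC cells (Homo sapiens), read by thymidine incorporation; a higher number here means a weaker inhibitor, a lower number a stronger inhibitor:
- compound 1 `CCCCCCCC/C=C\CCCCCCCC(=O)N[C@H]1[C@@H](OCCCCCCCC)O[C@H](CO)[C@@H](O)[C@@H]1O`: 13.3 uM
- compound 2 `CCCCCCCCCCCCCCCCO[C@H]1O[C@H](COCC(CO)(CO)COS(=O)(=O)O)[C@@H](O)[C@H](O)[C@H]1NC(=O)CCCC`: 3.2 uM

Compound 2, at 3.2 uM, holds the lower of the two numbers in this assay and is the stronger inhibitor of the pair. Its gap to compound 1 lies beyond the usual scatter.

The next compound to be read is compound 3 `CCCCCCCCCCCCCCCCO[C@H]1O[C@H](COCC(CO)(CO)CO)[C@@H](O)[C@H](O)[C@H]1NC(=O)CCCC`, which keeps the hexadecyl-bearing structure of compound 2 and changes it in one place: hydrogen in place of sulfo on an oxygen on a saturated carbon. In words, hydrogen takes the place of sulfo on an oxygen on a saturated carbon.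

Within the data shown here, no measured pair isolates this change, so any expectation rests on thin evidence. Compound 1 carries no sulfo group and gives 13.3 uM, but it also differs from compound 2 elsewhere, so it offers only a weak lean towards a higher number. The expected change is modest, in the direction of weaker inhibition, and could still fall within the scatter: a 2.5-fold higher number from compound 2 to compound 3 (0.40 log units; beyond the scatter) is the estimated step. For compound 3 the estimated value is 8 uM, with an expected range of 2.5 uM to 25 uM.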

Compound 3, concentration for 50% inhibition: 27.3 uM
The estimate for compound 3 lay 3.4-fold (0.53 log units) below the measured number; the measured number lies above the stated range.
By their numbers in this assay, from the lowest: compound 2; then compound 1; then compound 3.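

In this assay, among these compounds, the change from sulfooxy to hydroxy gives an 8.5-fold higher number from compound 2 to compound 3 (0.93 log units; beyond the scatter) and is the first pair to isolate one change, so the earlier contrast with compound 1 no longer has to serve as indirect evidence. The step lies beyond the usual scatter, which shows that inhibition at this position depends on what sits on the oxygen on a saturated carbon: with all else held constant, loss of the sulfo group alone makes compound 3 a weaker inhibitor than compound 2. No measurement in hand bears on the reason for this step.

The compounds shown leave open whether this depends on the sulfo group specifically or whether another group, such as a carboxylic acid or a phosphate in its place, would keep the number of compound 2 at 3.2 uM or near it. Going by these compounds, it also remains open whether the same step would appear with a chain other than hexadecyl, for example a longer chain on the same shared core.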